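Cinnamamide in place of an aryl amide on the shared core

This account rests on a few compounds, and the source may have more. Where it says the series, first, only, none or still open, it means among the compounds named here.

Compound 3 `Nc1ccc(C(=O)Nc2nnc(-c3ccc4c(c3)OCCO4)s2)cc1` stands in a functional assay on HeLa cells (Homo sapiens) for antiproliferative activity, read by MTT assay, with a stated time of 48 h (on this read-out lower numbers stand for an effect already at smaller amounts and higher numbers for an effect only at larger amounts of compound), only at a limit: in this assay compound 3 gives > 100 ug/mL, which is a limit and not a number. Compound 1 `Cc1ccccc1C(=O)Nc1nnc(-c2ccc3c(c2)OCCO3)s1` also sits at this limit, giving > 100 ug/mL in this assay. That matches (the limit of > 100 ug/mL in this assay, at which 2 of the 3 values shown sit). Among the measured compounds shown here, compound 2 `O=C(CCc1ccccc1)Nc1nnc(-c2ccc3c(c2)OCCO3)s1` is the one compound with a number, giving 32.5 ug/mL in this assay.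

Compound 4 `O=C(/C=C/c1ccccc1)Nc1nnc(-c2ccc3c(c2)OCCO3)s1` differs from compound 3 in one place: 2-phenylethenyl in place of 4-aminophenyl on a carbonyl carbon. For the measured compounds named here, two measured steps bear on this change. The step of an at least 3.0-fold higher number from compound 2 to compound 3 (0.48 log units; beyond the scatter) shows that replacing the phenethyl by an aromatic amide substituent moves the value up to the limit, and the step of an at least 3.0-fold lower number from compound 1 to compound 2 (0.48 log units; beyond the scatter) shows the same in the other direction. The step that the two limits leave unreadable from compound 1 to compound 3 is not readable. The group entering in compound 4 carries the phenyl of compound 2 on a two-carbon linker, as in compound 2, but with a double bond outside aromatic rings in that linker. Compound 4 is therefore expected to give a number rather than a limit, with a step of an at least 2.2-fold lower number from compound 3 to compound 4 (0.34 log units; beyond the scatter) that is estimated to lie beyond the scatter, downward. The expected value for compound 4 is 45 ug/mL, in a range from 15 ug/mL to 130 ug/mL.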

Compound 4, half-maximal effective concentration: > 100 ug/mL
Compound 4 ended at the assay's limit (the forecaster's own chance of this, stated with the estimate: 35%); middle value at least 2.2-fold (0.34 log units) from the limit.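

In this assay, among the compounds shown here, putting 2-phenylethenyl in place of phenethyl on the carbonyl carbon gives an at least 3.0-fold higher number from compound 2 to compound 4 (0.48 log units; beyond the scatter), so a phenyl on a two-carbon linker is not enough by itself to give a measurable value, and the double bond outside aromatic rings is the one difference in this pair. The result for compound 4 is a limit and not a number, and its steps to compound 1 and compound 3 cannot be read, so the aryl amides and the cinnamamide cannot be ranked against one another. Compound 2 is therefore the only compound with a number, and the position otherwise shows a single shared ceiling: the limit of > 100 ug/mL in this assay, at which 3 of the 4 values shown sit.

The compounds shown leave open whether the value of compound 2 depends on the length of the chain, which a benzyl or a 3-phenylpropyl group on the same carbonyl carbon would address. They also leave open how far the value of compound 2 can move when its phenyl carries a methoxy group, an amine or a carboxylic acid.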